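The source may report more compounds than this note shows. Statements on the series, on what has been measured and on what is new or still open speak of the compounds shown alone.

Measured so far:
compound 1 `C[C@]1(CN2CCc3nc(-c4ccc(F)c(F)c4)oc3C2)Cn2cc([N+](=O)[O-])nc2O1` — an ADME assay on Vero cells (Chlorocebus sabaeus) for cytotoxicity, read by MTT assay, with a stated time of 72 h; a lower number here means that less compound is tolerated, a higher number that more compound is tolerated: > 32 ug/mL
compound 2 `C[C@]1(CN2CCc3nc(-c4ccccc4F)ccc3C2)Cn2cc([N+](=O)[O-])nc2O1` — this assay: > 32 ug/mL

Compound 1 is recorded only as a limit of the assay, not as a number. Compound 2 is likewise recorded as a limit and not as a number. Both results sit at the limit of > 32 ug/mL in this assay, at which 2 of the 2 values shown sit. Compound 2 therefore has no numeric position of its own among the values shown: it stands at the same limit as compound 1, and the two cannot be ordered against each other. Going by the values given here, no step between measured compounds is available from this pair.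

Compound 3 `C[C@]1(CN2CCc3nc(-c4cc(Cl)ccc4F)ccc3C2)Cn2cc([N+](=O)[O-])nc2O1` is not yet measured. It differs from compound 2 by chloro in place of hydrogen on an aromatic carbon, the change reading 2-fluorophenyl to 5-chloro-2-fluorophenyl.

Without a measured step to lean on, the step from compound 2 to compound 3 in this assay is expected to be a step that the limit leaves unreadable from compound 2 to compound 3, that is, none beyond the scatter. Compound 3 is estimated at 40 ug/mL, within the range 20 ug/mL to 100 ug/mL, and the most likely outcome is that the assay again reports only the limit.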

Compound 3, half-maximal cytotoxic concentration: > 32 ug/mL
Compound 3 was reported as a limit; the forecaster's own chance of this, stated with the estimate: 80%; the middle value lies beyond the limit too.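

Going by these compounds alone, no step from compound 2 to compound 3 can be read in this assay, since both results are limits of the assay and not numbers: the limit of > 32 ug/mL in this assay, at which 3 of the 3 values shown sit.

The compounds shown leave open where any of the three stands numerically, and whether chloro in place of hydrogen on an aromatic carbon shifts the tolerated concentration at all.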